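This account rests on a few compounds, and the source may have more. Where it says the series, first, only, none or still open, it means among the compounds named here.

Compound 1 `O=C(Oc1ccc(Cl)cc1C(=O)Nc1ccc(C(F)(F)F)cc1)c1cnc(Cl)cn1` and compound 2 `O=C(Oc1ccc(Cl)cc1C(=O)Nc1ccc(Cl)c(Cl)c1)c1cnc(Cl)cn1` share one core and differ only in the group on the amide-type nitrogen. In a physicochemical assay for solubility, read by spectrophotometry (on this read-out higher numbers stand for higher solubility and lower numbers for lower solubility), compound 1 gives < 100000 nM, which is a limit of the assay. In this assay compound 2 likewise gives < 100000 nM, again a limit. The step that the two limits leave unreadable from compound 1 to compound 2 therefore cannot be read, as the limit of < 100000 nM in this assay, at which 2 of the 2 values shown sit, records. Compound 3 `O=C(Oc1ccc(Br)cc1C(=O)Nc1ccc(Cl)c(Cl)c1)c1cnc(Cl)cn1` differs from compound 2 by bromo in place of chloro on an aromatic carbon. Going by the values given here, no measured step bears on this change. Compound 3 is therefore expected to return another limit, estimated at 50000 nM with a range from 10000 nM to 100000 nM, meaning a step that the limit leaves unreadable from compound 2 to compound 3.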

Compound 3, solubility: < 100000 nM
Compound 3 was reported as a limit; the forecaster's own chance of this, stated with the estimate: 80%; the middle value lies beyond the limit too.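

In this assay, going by these compounds alone, compound 3 gives < 100000 nM as a limit, so no step from compound 2 to compound 3 can be read. The compounds shown leave open the actual solubility of all three and any difference between bromo and chloro.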